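The source may report more compounds than this note shows. Statements on the series, on what has been measured and on what is new or still open speak of the compounds shown alone.

Measured compounds:
compound 1 `C=CCn1c(=O)n(C(=O)NCCN2CCN(C)CC2)c2ccccc21` — < 6
compound 2 `CC(C)n1c(=O)n(C(=O)NN2CCN(C)CC2)c2ccccc21` — < 6

In a functional assay for antagonist activity at 5-hydroxytryptamine receptor 4 (Cavia porcellus) (a lower number here means a less potent compound, a higher number a more potent compound, by a factor of ten per unit of this negative logarithm), compound 1 gives < 6, which is a limit of the assay rather than a number. Compound 2 likewise gives only a limit in this assay. For the measured compounds named here, both values sit at the limit of < 6 in this assay, at which 2 of the 2 values shown sit, so no measured step shows how any change moves potency. Compound 3 `CN1CCN(CCNC(=O)n2c(=O)[nH]c3ccccc32)CC1` differs from compound 1 by hydrogen in place of allyl on an aromatic nitrogen, in words, hydrogen in place of allyl on an aromatic nitrogen. The expected step is a step that the limit leaves unreadable from compound 1 to compound 3, nothing beyond the scatter. Compound 3 is estimated at 5.5, between 4.5 and 6.3, most likely again only a limit.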

Compound 3, negative logarithm of the antagonist equilibrium constant: < 6
Compound 3 gave a limit, no number; the forecaster's own chance of this, stated with the estimate: 75%; the middle value lies beyond the limit too.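

Compound 1 and compound 3 each give only a limit of the assay, so no step between them can be read: the limit of < 6 in this assay, at which 3 of the 3 values shown sit.

Going by these compounds, whether hydrogen in place of allyl on an aromatic nitrogen changes potency at all stays open.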